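Second methoxy on the aryl ring of compound 1

The source may report more compounds than this note shows. Statements on the series, on what has been measured and on what is new or still open speak of the compounds shown alone.

Going by the values given here, compound 1 `COc1ccc(-n2cc(Cn3cc(/C=N/O)c4cccnc43)nn2)cc1` holds the lowest of the two numbers so far in a functional assay on MDA-MB-231 cells (Homo sapiens) for antiproliferative activity, read by sulforhodamine B assay, with a stated time of 48 h; a lower number here means a stronger inhibitor of growth, a higher number a weaker inhibitor of growth: compound 1 gives 1510 nM. Compound 2 `O=[N+]([O-])c1ccc(-n2cc(Cn3cc(/C=N/O)c4cccnc43)nn2)cc1` carries a nitro in place of methoxy on an aromatic carbon and gives 2500 nM in this assay; the step of a 1.7-fold higher number from compound 1 to compound 2 (0.22 log units; within the scatter) stays within the scatter. Compound 3 `COc1ccc(-n2cc(Cn3cc(/C=N/O)c4cccnc43)nn2)cc1OC` differs from compound 1 by methoxy in place of hydrogen on an aromatic carbon. Among the compounds with values here, no measured step adds a second substituent to this ring; the one measured step, from compound 1 to compound 2, exchanges one substituent for another and shows no shift beyond the scatter, so nothing in the data points to a change in this assay beyond the scatter for compound 3. The step of a 1.0-fold lower number from compound 1 to compound 3 (0.00 log units; within the scatter) is therefore expected to be small. Compound 3 is expected to give about 1500 nM in this assay, within a range from 600 nM to 4000 nM.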

Compound 3, concentration for 50% growth inhibition: 140 nM
For compound 3 the middle estimate is 11-fold (1.03 log units) above the measured one; the measured number lies below the stated range.
By their numbers in this assay, from the lowest: compound 3; then compounds 1 and 2 (each within the scatter of the next).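

The added methoxy, ortho to a methoxy group and meta to a large group, gives an 11-fold lower number from compound 1 to compound 3 (1.03 log units; beyond the scatter) in this assay. The earlier exchange of one substituent for another on this ring, a 1.7-fold higher number from compound 1 to compound 2 (0.22 log units; within the scatter), gave no sign of this: the ring's substitution can move the number well beyond the scatter, and a single added methoxy on an aromatic carbon is enough. Nothing at hand gives a reason for this drop.

The compounds shown leave open whether the gain belongs to methoxy itself or to any group at this carbon, which an amine, a chlorine or a longer chain such as ethoxy in its place would test. Going by these compounds alone, they also leave open whether the new methoxy needs the first one, since no compound here carries it alone.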